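Compound 3 to compound 4: a fluoro step

The source may hold more compounds than are shown below. What is called first, only, known or untested is meant among the compounds shown, and "the series" means these compounds.

Compound 1 `OC(c1ccc(Cl)cc1)(c1cccnc1)c1nccs1` gives > 100000 nM in an ADME assay on L6 cells (Rattus norvegicus) for cytotoxicity, read by resazurin assay, with a stated time of 72 h (a higher number here means a weaker inhibitor, a lower number a stronger inhibitor), as a limit of the assay. Compound 2 `OC(c1ccc(Cl)cc1)(c1cccnc1)c1cncnc1` gives > 100000 nM as a limit too. Compound 3 `CC(C)Oc1ncc(C(O)(c2ccc(Cl)cc2)c2cccnc2)cn1` gives > 100000 nM in this assay, again only a limit. All three therefore share one ceiling: the limit of > 100000 nM in this assay, at which 3 of the 3 values shown sit, with no number among them.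

Compound 4 `CC(C)Oc1ncc(C(O)(c2cccnc2)c2ccc(Cl)cc2F)cn1` carries fluoro in place of hydrogen on an aromatic carbon is the whole change. The measured steps, a step that the two limits leave unreadable from compound 1 to compound 2 and a step that the two limits leave unreadable from compound 2 to compound 3, offer no size to carry over. The estimated change is a number no higher from compound 3 to compound 4 (the limit leaves the size open) with no step beyond the scatter expected. Compound 4 is estimated at 100000 nM with an expected range of 40000 nM to 200000 nM in this assay here.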

Compound 4, half-maximal inhibitory concentration: 89500 nM
Compound 4: middle estimate off by 1.1-fold (0.05 log units), on the high side; measured number inside the range.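

In this assay, going by these compounds alone, fluoro on the aromatic carbon ortho to a large group, 4-chlorophenyl to 4-chloro-2-fluorophenyl, gives the first step with any readable size: an at least 1.1-fold lower number from compound 3 to compound 4 (0.04 log units; that floor lies within the scatter). Within the data shown here, the earlier steps cannot be read, and compound 4 is the first compound to carry a number rather than a limit. The other compounds share one ceiling: the limit of > 100000 nM in this assay, at which 3 of the 4 values shown sit.

Going by these compounds, how large the step truly is stays open, since compound 3 holds only a limit. On these data alone, whether methoxy or an amine at this place would move the number further also stays open.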